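A few compounds are considered here, and "the series" means these few. Any claim that something is new, unique, unknown or untested is made for them only; others in the source may bear on it.

- compound 1 `C[C@]1(O)C[C@](c2cccc(C(F)(F)F)c2)([C@H](O)c2ccccn2)C1` gives 33.3 mL/min/kg
- compound 2 `C[C@]1(O)C[C@@](c2cc(C(F)(F)F)ccn2)([C@H](O)c2ccccn2)C1` gives 33.3 mL/min/kg
- compound 3 `O[C@H](c1ccccn1)[C@]1(c2cc(C(F)(F)F)ccn2)C[C@@H](O)C1` gives 33.3 mL/min/kg

All three were read in an ADME assay on liver for metabolic stability, with Liver microsome (Homo sapiens) as the target, read by LC-MS, using microsomes, with a stated time of 5 h (on this read-out higher numbers stand for fast clearance and lower numbers for slow clearance), and compound 2 stands level with compound 1 and compound 3 at the digits reported. The next compound to be read is compound 4 `C[C@]1(O)C[C@](c2cc(C(F)(F)F)ccn2)([C@@H](O)c2ccccn2)C1`, which is set against compound 2. The structural difference is this: the two compounds have the same atoms and bonds and differ only in configuration as drawn: 2 of 3 stereo elements differ; a stereocentre at a saturated ring carbon is drawn s in compound 2 and r in compound 4; a stereocentre at a saturated chain carbon is drawn S in compound 2 and R in compound 4. No group leaves or enters.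

Within the data shown here, only one measured step starts from compound 2: no change at the digits printed from compound 2 to compound 3 (within the scatter), where hydrogen takes the place of methyl on a saturated ring carbon. That step changes atoms rather than configuration, so it bears on the new comparison only indirectly. Among the measured compounds shown here, no pair differing only in configuration has yet been measured, which leaves the expectation loosely founded. With nothing beyond the scatter among the three values, no direction is favoured. The expected 1.0-fold lower number from compound 2 to compound 4 (0.00 log units; within the scatter) is therefore no larger than the scatter. The estimated value for compound 4 is 33 mL/min/kg, with an expected range from 18 mL/min/kg to 55 mL/min/kg in this assay.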

Compound 4, clearance: 33.3 mL/min/kg
Compound 4: the middle estimate sits 1.0-fold (0.00 log units) below what was measured, and the stated range covers the measured number.
By their numbers in this assay, from the lowest: compounds 1, 2, 3 and 4 (each within the scatter of the next).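

Among these compounds, compound 4 gives the first reading on configuration, since the earlier step changed atoms rather than stereochemistry. With two of the three stereo elements drawn differently, the clearance in this assay shows no change at the digits printed from compound 2 to compound 4 (within the scatter), so this change of configuration at the saturated ring carbon and the saturated chain carbon together leaves the read-out level at the digits printed. The comparison bears on configuration alone, with no group leaving or entering: the fact that compounds 2 and 4 differ only in the configuration as drawn.

The compounds shown leave open whether changing either stereocentre alone, or the remaining stereo element, would separate the values in this assay. Among the compounds shown here, they also leave open whether an amine or a carboxylic acid on the shared core would give a number different from the one that all four compounds share.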